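Triazolylmethyl amide series: aryl substituent survey in HepG2 cells

The source may report more compounds than this note shows. Statements on the series, on what has been measured and on what is new or still open speak of the compounds shown alone.

compound 1 `CC(C)n1ncc2c(C(=O)NCc3cn(-c4ccc(F)cc4)nn3)cccc21` — > 40000 nM
compound 2 `Cc1ccc(-n2cc(CNC(=O)c3cccc4c3cnn4C(C)C)nn2)cc1` — > 40000 nM
compound 3 `Cc1ccccc1-n1cc(CNC(=O)c2cccc3c2cnn3C(C)C)nn1` — > 40000 nM

All three measured compounds share the core of compound 1 and differ only in the aryl group on an aromatic nitrogen. In a functional assay on HepG2 cells (Homo sapiens) for inhibition, read by MTT assay, with a stated time of 72 h (a lower number here means a stronger inhibitor, a higher number a weaker inhibitor), each of the three values is a limit of the assay, not a number: compound 1 sits at the limit, compound 2 sits at the limit, and compound 3 sits at the limit, as summarised by the limit of > 40000 nM in this assay, at which 3 of the 3 values shown sit. The change fluoro in place of methyl on an aromatic carbon therefore gives a step that the two limits leave unreadable from compound 2 to compound 1, the change 2-methylphenyl in place of 4-methylphenyl on an aromatic nitrogen gives a step that the two limits leave unreadable from compound 2 to compound 3, and a step that the two limits leave unreadable from compound 1 to compound 3 is likewise unreadable.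

Compound 4 `CC(C)n1ncc2c(C(=O)NCc3cn(-c4ccccc4F)nn3)cccc21` is not yet measured. It differs from compound 3 by fluoro in place of methyl on an aromatic carbon, the same kind of change as from compound 2 to compound 1, but the place differs: there the fluoro stood para to a large group, here it stands ortho to a large group. With all three measured values at the limit, the expectation for compound 4 rests only on that pattern, so an inactive result is expected, with a step that the limit leaves unreadable from compound 3 to compound 4 and an estimated value of 60000 nM.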

Compound 4, half-maximal inhibitory concentration: > 40000 nM
Compound 4: no number, only a limit; the forecaster's own chance of this, stated with the estimate: 85%; the middle value does not contradict the limit.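

In this assay compound 4 gives > 40000 nM, which is a limit and not a number, so no step between it and compound 1, compound 2 or compound 3 can be read: the limit of > 40000 nM in this assay, at which 4 of the 4 values shown sit.

The compounds shown leave open whether any aryl group on the shared core gives a readable value in this assay.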